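Series notes: aryl to benzyl change on the shared core

The source may report more compounds than this note shows. Statements on the series, on what has been measured and on what is new or still open speak of the compounds shown alone.

Compound 1 `C=C(Br)C(=O)Nc1cccc(-c2cn3nc(-c4ccc(OCC)cc4)sc3n2)c1` has the lowest number of the two measured in a functional assay on FM3A cells (Mus musculus) for inhibition, read by cell counting, with a stated time of 2 days; a higher number here means a weaker inhibitor, a lower number a stronger inhibitor: in this assay compound 1 gives 1100 nM. Compound 2 `COc1cccc(-c2nn3cc(-c4cccc(N)c4)nc3s2)c1` gives 29000 nM in this assay, a higher number. Among the compounds with values here, no measured pair differing in one place is available. Compound 3 `C=C(Br)C(=O)Nc1cccc(-c2cn3nc(Cc4ccc(OC)cc4)sc3n2)c1` differs from compound 1 by 4-methoxybenzyl in place of 4-ethoxyphenyl on an aromatic carbon. For compound 3 the expectation is a modest step toward a higher number in this assay, a 2.7-fold higher number from compound 1 to compound 3 (0.44 log units; beyond the scatter), though it may fall within the scatter. Compound 3 is thus estimated at 3000 nM, with a range from 1000 nM to 12000 nM.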

Compound 3, half-maximal inhibitory concentration: 850 nM
Compound 3: the middle estimate sits 3.5-fold (0.55 log units) above what was measured; the measured number lies below the stated range.
By their numbers in this assay, from the lowest: compounds 3 and 1 (each within the scatter of the next); then compound 2.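

In this assay, 4-methoxybenzyl in place of 4-ethoxyphenyl on this aromatic carbon of the shared core gives a 1.3-fold lower number from compound 1 to compound 3 (0.11 log units; within the scatter). The position thus accepts a benzyl group as well as a directly attached aryl group, with no readable difference between the two. No measured evidence accounts for this result. On these data alone, the step changes both the link to the ring and the ether chain at once, so the contribution of each remains open. A 4-methoxyphenyl group would separate the two, and an amine on the benzyl ring would test how much polar substitution this position accepts.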